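Changing the Aryl Group on the Ring Nitrogen

The compounds below may be only part of what the source reports. "The series", "measured", "known", "first", "only" and "open" are said of these compounds alone.

Measured compounds:
compound 1, `CCOc1ccccc1-n1nncc1CN1C(=O)C2(C(C#N)=C(N)Oc3c2c2nc4ccccc4nc2c2ccccc32)c2ccccc21`, gives > 50000 nM in an ADME assay on HUVEC cells (Homo sapiens) for antiproliferative activity, read by MTT assay, with a stated time of 48 h; on this read-out higher numbers stand for weaker inhibition and lower numbers for stronger inhibition
compound 2, `N#CC1=C(N)Oc2c(c3nc4ccccc4nc3c3ccccc23)C12C(=O)N(Cc1cnnn1-c1ccc(N)cc1)c1ccccc12`, gives > 50000 nM in this assay
compound 3, `CC(=O)Nc1ccc(-n2nncc2CN2C(=O)C3(C(C#N)=C(N)Oc4c3c3nc5ccccc5nc3c3ccccc43)c3ccccc32)cc1`, gives > 50000 nM in this assay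

Compound 3 stands at a limit in this assay: its value of > 50000 nM is a limit of the assay and not a number. The same holds for the other two values, since (the limit of > 50000 nM in this assay, at which 3 of the 3 values shown sit). Between these compounds the steps a step that the two limits leave unreadable from compound 1 to compound 2, a step that the two limits leave unreadable from compound 1 to compound 3 and a step that the two limits leave unreadable from compound 2 to compound 3 are therefore unreadable in size; they show only that none of the three aryl groups on the ring nitrogen brought the value down into the readable range.

Compound 4, `N#CC1=C(N)Oc2c(c3nc4ccccc4nc3c3ccccc23)C12C(=O)N(Cc1cnnn1-c1cccc(S(N)(=O)=O)c1)c1ccccc12`, differs from compound 3 in one place: 3-sulfamoylphenyl in place of 4-acetamidophenyl on an aromatic nitrogen. Going by the values given here, all three measured steps touch the same position, and all of them leave the limit unchanged, so no step in this assay beyond the scatter is expected from this exchange. Compound 4 is therefore expected to remain at the limit as well, with an estimated value of 80000 nM in a range from 20000 nM to 300000 nM. The expected step that the limit leaves unreadable from compound 3 to compound 4 is accordingly estimated to be none beyond the scatter.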

Compound 4, half-maximal inhibitory concentration: 38600 nM
Estimate against measurement, compound 4: 2.1-fold (0.32 log units) above; measured number inside the range.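

Going by these compounds alone, compound 4, with 3-sulfamoylphenyl on the aromatic nitrogen, is the only one of the four compounds that gives a number rather than a limit in this assay, so this position can carry an aryl group whose value falls in the readable range. Its exchange for the other aryl groups gives an at least 1.2-fold lower number from compound 3 to compound 4 (0.11 log units; that floor lies within the scatter), an at least 1.2-fold lower number from compound 2 to compound 4 (0.11 log units; that floor lies within the scatter) and an at least 1.2-fold lower number from compound 1 to compound 4 (0.11 log units; that floor lies within the scatter). On these data alone, these steps therefore do not establish a change beyond the scatter, and their true size stays unknown because the other compound in each pair stands at a limit: the limit of > 50000 nM in this assay, at which 3 of the 4 values shown sit.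

The compounds shown do not separate the effect of the sulfamoyl group from that of where it sits on the phenyl ring, as compound 4 differs from the other compounds in both respects. They also leave open how a carboxylic acid or a methylsulfonyl group in place of the sulfamoyl group would read in this assay, and so whether the readable value is particular to the sulfamoyl group.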